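Extending the chain on compound 1

The source may report more compounds than this note shows. Statements on the series, on what has been measured and on what is new or still open speak of the compounds shown alone.

In a functional assay on PC-3 cells (Homo sapiens) for antiproliferative activity, read by MTT assay, with a stated time of 72 h (on this read-out lower numbers stand for stronger inhibition and higher numbers for weaker inhibition), compound 1 (`CCCCCCCNC[C@@H]1OC[C@H](N)[C@@H]1O`) gives 22400 nM and compound 3 (`CCCCCCCCNC[C@@H]1OC[C@H](N)[C@H]1O`) gives 13000 nM, two values within the scatter of each other. Compound 2 (`CCCCCCCNC[C@@H]1OC[C@H](N)[C@H]1O`) gives > 128000 nM, which is a limit of the assay and not a number.

Compound 4 (`CCCCCCCCCNC[C@@H]1OC[C@H](N)[C@@H]1O`) is not yet measured. It differs from compound 1 as follows: ethyl in place of hydrogen on a saturated chain carbon, seven bonds along the chain from an amine nitrogen.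

For the measured compounds named here, two measured steps bear on this change. The first is an at least 5.7-fold higher number from compound 1 to compound 2 (0.75 log units; beyond the scatter), and it comes with the fact that compounds 1 and 2 differ only in the configuration as drawn. Going by the values given here, the second is the only chain step available, an at least 9.8-fold lower number from compound 2 to compound 3 (0.99 log units; beyond the scatter), which places methyl at the same chain position but in the configuration of compound 2. Both sizes rest on a limit, so neither transfers directly. Compound 4 keeps the configuration of compound 1, so only the direction of an at least 9.8-fold lower number from compound 2 to compound 3 (0.99 log units; beyond the scatter) is carried over, and a smaller gain is expected.

The expected step is a 3.7-fold lower number from compound 1 to compound 4 (0.57 log units; beyond the scatter).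

The estimate in this assay for compound 4 is 6000 nM, with an expected range of 1800 nM to 18000 nM.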

Compound 4, half-maximal inhibitory concentration: 2030 nM
Compound 4: the middle estimate sits 3.0-fold (0.47 log units) above what was measured; measured number inside the range.
By their numbers in this assay, from the lowest: compound 4; then compounds 3 and 1 (each within the scatter of the next). At a limit, above all of these: compound 2.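

Ethyl in place of hydrogen on a saturated chain carbon, seven bonds along the chain from an amine nitrogen, gives an 11-fold lower number from compound 1 to compound 4 (1.04 log units; beyond the scatter) in this assay. This is the first chain step shown with a number at both ends, so the position's response to added carbon now has a size in the configuration of compound 1. The earlier chain step, an at least 9.8-fold lower number from compound 2 to compound 3 (0.99 log units; beyond the scatter), gave only a bound and began from a limit: the limit of > 128000 nM in this assay, at which 1 of the 4 values shown sits.

For the compounds shown here, the single step in this configuration shows no trend with chain length, and whether a longer chain continues the gain or reverses it remains open. Also open, going by these compounds, is how the response would change with a carboxylic acid or a phenyl ring at the chain end in place of the terminal methyl.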